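The source may hold more compounds than are shown below. What is called first, only, known or untested is meant among the compounds shown, and "the series" means these compounds.

Compound 1 `COc1ccc(C(=O)N2CCN(CC(=O)N3CCN(CCCc4c[nH]c5ccccc45)CC3)CC2)cc1`: 148000 nM
Compound 2 `O=C(CN1CCN(C(=O)c2ccc(F)cc2)CC1)N1CCN(CCCc2c[nH]c3ccccc23)CC1`: 188000 nM
Compound 3 `O=C(CN1CCN(C(=O)c2ccccc2)CC1)N1CCN(CCCc2c[nH]c3ccc(F)cc23)CC1`: 146000 nM

These three numbers come from an ADME assay on SH-SY5Y cells (Homo sapiens) for cytotoxicity, read by MTT assay, with a stated time of 72 h (on this read-out lower numbers stand for stronger inhibition and higher numbers for weaker inhibition), and all of them lie within the usual scatter of one another, so none of the three compounds can be called more or less active than the others. Compound 2 and compound 3 are built from the same atoms joined differently; the difference between the two cores is not broken down here. Compound 1 arises from compound 2 by one change, (methoxy in place of fluoro on an aromatic carbon), and that change gave a 1.3-fold lower number from compound 2 to compound 1 (0.10 log units; within the scatter). Compound 4 `COc1ccc2[nH]cc(CCCN3CCN(C(=O)CN4CCN(C(=O)c5ccccc5)CC4)CC3)c2c1` has not yet been measured. It arises from compound 3 by methoxy in place of fluoro on an aromatic carbon. This is the same kind of change, but at a different place: in compound 1 the ring carbon is para to a large group, whereas in compound 4 it sits in a six-membered aromatic ring of carbon only that is part of a fused or bridged system of two rings, meta to a fused ring and para to a fused ring. The step is expected to be about as small as the earlier one, a 1.1-fold lower number from compound 3 to compound 4 (0.05 log units; within the scatter), because the same kind of change gave a 1.3-fold lower number from compound 2 to compound 1 (0.10 log units; within the scatter). Compound 4 is therefore estimated at 130000 nM in this assay, with a likely range from 70000 nM to 250000 nM.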

Compound 4, half-maximal inhibitory concentration: > 200000 nM
Compound 4: only a limit was reported; the forecaster's own chance of this, stated with the estimate: 15%; at least 1.5-fold (0.18 log units) between middle value and limit.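

In this assay compound 4 gives > 200000 nM, which is a limit of the assay and not a number. The new step therefore reads an at least 1.3-fold higher number from compound 3 to compound 4 (0.13 log units; that floor lies within the scatter), a floor rather than a true size, and that floor lies within the usual scatter. So methoxy in place of fluoro has been tried on two cores, at two different places, and this pair of results neither shows that the change carries over from one core to the other nor shows that it fails to: the same change on two cores in this assay, a 1.3-fold lower number (0.10 log units; within the scatter) from compound 2 to compound 1 and an at least 1.3-fold higher number (0.13 log units; that floor lies within the scatter) from compound 3 to compound 4; the limit leaves it open whether they differ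

The compounds shown leave open how large the step on the core of compound 3 really is, since only a value for compound 4 inside the measurable range could settle that. They also leave open how other groups would read on the same aromatic carbon, such as chloro, hydroxy or an amine, and whether fluoro and methoxy would compare the same way at one shared place on a single core.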